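Trimming the polyol tail: from compound 2 to compound 4

The source may hold more compounds than are shown below. What is called first, only, known or untested is meant among the compounds shown, and "the series" means these compounds.

The series shares the core of compound 1 `CC[C@H](C)[C@@H](O)C(=O)O[C@@H](C(=O)O[C@@H](C(=O)O[C@@H](C(=O)O[C@@H](C(=O)OC[C@@H](O)[C@@H](O)CO)[C@@H](C)CC)[C@@H](C)CC)[C@@H](C)CC)[C@@H](C)CC`, an ester chain closed by a polyhydroxylated tail. In a functional assay on HepG2 cells (Homo sapiens) for cytotoxicity, read by MTT assay, with a stated time of 24 h (on this read-out higher numbers stand for weaker inhibition and lower numbers for stronger inhibition), compound 1 gives 28700 nM. Compound 2 `CC[C@H](C)[C@@H](O)C(=O)O[C@@H](C(=O)O[C@@H](C(=O)O[C@@H](C(=O)O[C@@H](C(=O)O[C@@H]([C@H](O)[C@H](O)CO)[C@H](O)CO)[C@@H](C)CC)[C@@H](C)CC)[C@@H](C)CC)[C@@H](C)CC` reaches only a limit of the assay, > 53200 nM. Compound 3 `CC[C@H](C)[C@@H](O)C(=O)O[C@@H](C(=O)O[C@@H](C(=O)O[C@@H](C(=O)O[C@@H](C(=O)OC[C@@H](O)[C@@H](O)[C@H](O)[C@H](O)CO)[C@@H](C)CC)[C@@H](C)CC)[C@@H](C)CC)[C@@H](C)CC` likewise reaches only a limit, > 53200 nM. The measured steps are therefore read against the limit of > 53200 nM in this assay, at which 2 of the 3 values shown sit: an at least 1.8-fold higher number from compound 1 to compound 2 (0.26 log units; that floor lies within the scatter), an at least 1.8-fold higher number from compound 1 to compound 3 (0.26 log units; that floor lies within the scatter), and a step that the two limits leave unreadable from compound 2 to compound 3. Compound 4 `CC[C@H](C)[C@@H](O)C(=O)O[C@@H](C(=O)O[C@@H](C(=O)O[C@@H](C(=O)O[C@@H](C(=O)O[C@H](CO)[C@@H](O)[C@H](O)CO)[C@@H](C)CC)[C@@H](C)CC)[C@@H](C)CC)[C@@H](C)CC` differs from compound 2 by 2,3,4-trihydroxy-1-(hydroxymethyl)butyl in place of 1-(1,2-dihydroxyethyl)-2,3,4-trihydroxybutyl on an oxygen next to a carbonyl group. Both changes out of compound 1 ran toward the limit, so compound 4 is expected to sit near that limit as well, with the step of an at least 1.1-fold lower number from compound 2 to compound 4 (0.07 log units; that floor lies within the scatter) expected to stay small and of uncertain direction. The estimate for compound 4 is 45000 nM, between 20000 nM and 100000 nM.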

Compound 4, half-maximal inhibitory concentration: 26200 nM
Compound 4: the middle estimate sits 1.7-fold (0.23 log units) above what was measured; the measured number falls inside the stated range.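

In this assay, the tail on the oxygen next to a carbonyl group can take the form 2,3,4-trihydroxy-1-(hydroxymethyl)butyl and still give a readable number, with a 1.1-fold lower number from compound 1 to compound 4 (0.04 log units; within the scatter) and thus no separation between these two tails. Against the two compounds held at a limit, only floors can be read, an at least 2.0-fold lower number from compound 2 to compound 4 (0.30 log units; that floor lies within the scatter) and an at least 2.0-fold lower number from compound 3 to compound 4 (0.30 log units; that floor lies within the scatter), and neither floor clears the scatter: the limit of > 53200 nM in this assay, at which 2 of the 4 values shown sit. The compounds shown leave open whether an amine or a carboxylic acid on this tail would shift the number.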